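Trifluoromethyl in place of isopropoxy: working notes

The source may report more compounds than this note shows. Statements on the series, on what has been measured and on what is new or still open speak of the compounds shown alone.

Of the compounds shown here, two have so far been read in an ADME assay on BJ cells (Homo sapiens) for cytotoxicity, read by luminescence, with a stated time of 72 h; on this read-out lower numbers stand for an effect already at smaller amounts and higher numbers for an effect only at larger amounts of compound. Compound 1 (`CCOC(=O)c1c(-c2cc(F)cc(OC)c2)[nH]c2cc(OC)ccc2c1=O`) gives > 21500 nM, which is a limit of the assay and not a number. Compound 2 (`CCOC(=O)c1c(-c2cccc(OC(C)C)c2)[nH]c2cc(OC)ccc2c1=O`) gives > 21500 nM, which is likewise a limit and not a number. The whole record so far is therefore (the limit of > 21500 nM in this assay, at which 2 of the 2 values shown sit), so compound 2 has a bound but no numerical position, and no order can be drawn between the two compounds.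

Compound 3 (`CCOC(=O)c1c(-c2cccc(C(F)(F)F)c2)[nH]c2cc(OC)ccc2c1=O`) differs from compound 2 in one place: trifluoromethyl in place of isopropoxy on an aromatic carbon. The change is trifluoromethyl in place of isopropoxy on an aromatic carbon, meta to a large group. For the measured compounds named here, no measured pair shows this exchange, so the expectation rests only on the limit shared by compound 1 and compound 2. In this assay, no step beyond the usual scatter is expected, and no direction is favoured. The expected change is a step that the limit leaves unreadable from compound 2 to compound 3. Another reading as a limit is also expected to be the likelier outcome. For compound 3 the estimate is 25000 nM, with an expected range from 11000 nM to 50000 nM.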

Compound 3, half-maximal effective concentration: > 21500 nM
Compound 3 gave a limit, no number; the forecaster's own chance of this, stated with the estimate: 75%; the middle value does not contradict the limit.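

For the compounds shown here, no step from compound 2 to compound 3 can be read in this assay, since both results are limits and not numbers, and the record now reads: the limit of > 21500 nM in this assay, at which 3 of the 3 values shown sit. The compounds shown leave open where any of the three would fall as a number in this assay, and whether trifluoromethyl in place of isopropoxy changes the read-out at all.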